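Tolerance limit and the methoxy change on compound 2

The source may report more compounds than this note shows. Statements on the series, on what has been measured and on what is new or still open speak of the compounds shown alone.

Of the compounds shown here, two on the shared core have been read in an ADME assay on MDBK cells (Bos taurus) for cytotoxicity, read by MTT assay; a higher number here means that more compound is tolerated, a lower number that less compound is tolerated. Compound 1 `OC[C@@H]1[C@@H](O)[C@H](O)[C@@H](O)CN1CC/C=C\CCOc1cc(F)ccc1F` gives > 500000 nM, a limit of the assay and not a number. Compound 2 `OC[C@@H]1[C@@H](O)[C@H](O)[C@@H](O)CN1CCCCCCOc1ccccc1C(F)(F)F` gives > 500000 nM, likewise a limit and not a number. Compound 2 therefore has no number of its own, only (the limit of > 500000 nM in this assay, at which 2 of the 2 values shown sit).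

Compound 3 `COc1ccccc1OCCCCCCN1C[C@H](O)[C@@H](O)[C@H](O)[C@H]1CO` follows from compound 2 by one change: methoxy in place of trifluoromethyl on an aromatic carbon. In words, methoxy stands in place of trifluoromethyl on an aromatic carbon. Within the data shown here, no measured pair shows the size of such a change. The expectation rests on compound 2, whose reading of > 500000 nM is a limit. The estimated step of a number no higher from compound 2 to compound 3 (the limit leaves the size open) in this assay is expected to stay within the usual scatter, and another limit reading is likely. For compound 3 the expected value is 500000 nM, with an estimated range of 250000 nM to 1000000 nM.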

Compound 3, half-maximal cytotoxic concentration: > 500000 nM
Compound 3: only a limit was reported (the forecaster's own chance of this, stated with the estimate: 85%); the middle value lies on the limit itself.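

Compound 2 and compound 3 both give only limits in this assay, so no step between them can be read: the limit of > 500000 nM in this assay, at which 3 of the 3 values shown sit.

The compounds shown leave open at what concentration any of them stops being tolerated, and whether methoxy in place of trifluoromethyl shifts that concentration at all.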